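This account rests on a few compounds, and the source may have more. Where it says the series, first, only, none or still open, it means among the compounds named here.

Three compounds sharing one core were tested in an ADME assay on SK-OV-3 cells (Homo sapiens) for cytotoxicity, read by sulforhodamine B assay, with a stated time of 48 h, tested at 10 uM; on this read-out higher numbers stand for more inhibition at the one concentration tested (going by the name of the read-out) and lower numbers for less inhibition. Compound 1 `CCCCCCc1cn(C(c2ccccc2)c2cc3cc(Br)ccc3nc2OC)nn1` gives 7.17% in this assay, compound 2 `CCCCCCCCc1cn(C(c2ccccc2)c2cc3cc(Br)ccc3nc2OC)nn1` gives 2.06%, and compound 3 `CCOC(=O)c1cn(C(c2ccccc2)c2cc3cc(Br)ccc3nc2OC)nn1` gives 2.01%. Compound 3 stands lowest of the three, though every gap is small: the step from compound 1 to compound 3 is a number 5.2 percentage points lower from compound 1 to compound 3 (within the scatter) and that from compound 2 to compound 3 is a number 0.1 percentage points lower from compound 2 to compound 3 (within the scatter), both within the scatter of the measurement.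

Compound 4 `COc1nc2ccc(Br)cc2cc1C(c1ccccc1)n1cc(-c2ccc(OC(F)(F)F)cc2)nn1` is not yet measured. It differs from compound 3 in one place: 4-(trifluoromethoxy)phenyl in place of ethoxycarbonyl on an aromatic carbon. The measured steps that touch the same aromatic carbon are the replacement of hexyl by ethoxycarbonyl, a number 5.2 percentage points lower from compound 1 to compound 3 (within the scatter), and of octyl by ethoxycarbonyl, a number 0.1 percentage points lower from compound 2 to compound 3 (within the scatter), neither beyond the scatter. Among the measured compounds shown here, no measured step brings in a ring at this carbon, so the expectation rests on the flatness seen so far. In this assay compound 4 is therefore expected to sit close to compound 3, with an estimated step of a number 4 percentage points higher from compound 3 to compound 4 (within the scatter), and its estimated value is 6%, ranging from -4% to 20%.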

Compound 4, a percentage reported as inhibition, at one concentration (the size of the read-out at that concentration, not a potency): 14.8%
Beside the measured number, compound 4's estimate is 8.8 percentage points below it, and the stated range covers the measured number.
By their numbers in this assay, from the lowest: compounds 3, 2, 1 and 4 (each within the scatter of the next, the first and the last beyond it).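

Among the compounds shown here, at this aromatic carbon of the five-membered ring with 3 nitrogen, bringing in a ring produces the first steps beyond the scatter in this assay: 4-(trifluoromethoxy)phenyl in place of ethoxycarbonyl gives a number 12.8 percentage points higher from compound 3 to compound 4 (beyond the scatter), and in place of octyl it gives a number 12.7 percentage points higher from compound 2 to compound 4 (beyond the scatter). The same change from hexyl gives a number 7.6 percentage points higher from compound 1 to compound 4 (within the scatter), so compound 4 cannot be told apart from compound 1, and the position's response depends on which group is compared. Nothing measured here gives a reason for these steps.

The compounds shown leave open whether the ring alone or the trifluoromethoxy group on it carries the rise, which a plain phenyl at this carbon could settle. They also leave open what an amine or a carboxylic acid on that ring would do.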